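Removing the ring fluorine on a second permeability core

The source may hold more compounds than are shown below. What is called first, only, known or untested is meant among the compounds shown, and "the series" means these compounds.

Compound 1 `O=C(NCc1cc(Cl)ccc1-n1cnnn1)[C@@H]1CC=NN1C(=O)[C@H](O)c1ccccc1F` shows, in an ADME assay on Caco-2 cells (Homo sapiens) for permeability, read by LC-MS, in the apical to basolateral direction, with a stated time of 60 min, at pH 6.5 (on this read-out lower numbers stand for lower permeability and higher numbers for higher permeability), a value of 8.9 10^-6 cm/s. Compound 2 `O=C(NCc1cc(Cl)ccc1-n1cnnn1)[C@@H]1CC=NN1C(=O)[C@H](O)c1ccccc1` differs from it only by hydrogen in place of fluoro on an aromatic carbon, and in this assay compound 2 gives 7 10^-6 cm/s, a step of a 1.3-fold lower number from compound 1 to compound 2 (0.10 log units; within the scatter). Compound 3 `O=C(NCc1cc(Cl)ccc1-n1cnnn1)[C@@H]1[C@@H]2C[C@@H]2CN1C(=O)[C@H](O)c1ccccc1F` carries a different core; how the two cores differ is not broken down here. In this assay compound 3 gives 2.3 10^-6 cm/s. Compound 4 `O=C(NCc1cc(Cl)ccc1-n1cnnn1)[C@@H]1[C@@H]2C[C@@H]2CN1C(=O)[C@H](O)c1ccccc1` is related to compound 3 by hydrogen in place of fluoro on an aromatic carbon, at the same place as the earlier change, so it is the same change made on the second core. Because the earlier step was a 1.3-fold lower number from compound 1 to compound 2 (0.10 log units; within the scatter), the step expected here is a 1.2-fold lower number from compound 3 to compound 4 (0.08 log units; within the scatter). The value of compound 4 in this assay is therefore estimated at 1.9 10^-6 cm/s, most likely between 0.9 10^-6 cm/s and 3.5 10^-6 cm/s.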

Compound 4, apparent permeability: 2.2 10^-6 cm/s
For compound 4 the middle estimate is 1.2-fold (0.06 log units) below the measured one; measured number inside the range.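

Replacing fluoro with hydrogen on the second core, the change from 2-fluorophenyl to phenyl, gives in this assay a 1.0-fold lower number from compound 3 to compound 4 (0.02 log units; within the scatter), so this read-out does not separate the pair. Across the two cores, the change behaves alike: the same change on two cores in this assay, a 1.3-fold lower number (0.10 log units; within the scatter) from compound 1 to compound 2 and a 1.0-fold lower number (0.02 log units; within the scatter) from compound 3 to compound 4, 1.2-fold (0.08 log units) apart, within the scatter of two such steps. This shows that the change made no readable difference on either core in this one assay, but it does not show that the same would hold on other cores or in other assays.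

The compounds shown carry only fluoro or hydrogen at this place on the ring. On these data alone, how a chloro, a methoxy or an amine there would read in this assay stays open.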